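Benzyl aryl variation in a sulfonamide diamine series

A few compounds are considered here, and "the series" means these few. Any claim that something is new, unique, unknown or untested is made for them only; others in the source may bear on it.

Measured so far, in a functional assay on BXPC-3 cells (Homo sapiens) for inhibition, read by MTT assay, with a stated time of 72 h; a lower number here means a stronger inhibitor of growth, a higher number a weaker inhibitor of growth:
compound 1 `O=S(=O)(NCCCNCc1ccccc1Cl)c1cc(C(F)(F)F)cc(C(F)(F)F)c1`: 11000 nM
compound 2 `CC(C)(C)c1ccc(CNCCCNS(=O)(=O)c2cc(C(F)(F)F)cc(C(F)(F)F)c2)cc1`: 1400 nM
compound 3 `O=S(=O)(NCCCNCc1ccc(Cl)c(Cl)c1)c1cc(C(F)(F)F)cc(C(F)(F)F)c1`: 1400 nM

Compound 2 and compound 3 sit level at the digits printed, together the lowest two numbers; compound 1 is the furthest from them. The two steps away from compound 1 are the same size, a 7.9-fold lower number from compound 1 to compound 2 (0.90 log units; beyond the scatter) and a 7.9-fold lower number from compound 1 to compound 3 (0.90 log units; beyond the scatter), whereas no change at the digits printed from compound 2 to compound 3 (within the scatter).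

Compound 4 `O=S(=O)(NCCCNCc1ccc(-c2ccccc2)cc1)c1cc(C(F)(F)F)cc(C(F)(F)F)c1` carries phenyl in place of tert-butyl on an aromatic carbon. Among the compounds with values here, no measured step exchanges one group for another at this same position; the only step between the two lowest compounds, no change at the digits printed from compound 2 to compound 3 (within the scatter), moves the substituent pattern without shifting the number. The expectation is therefore a 1.1-fold lower number from compound 2 to compound 4 (0.03 log units; within the scatter). Compound 4 is estimated at 1300 nM, within 400 nM to 4500 nM.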

Compound 4, concentration for 50% growth inhibition: 1700 nM
The estimate for compound 4 lay 1.3-fold (0.12 log units) below the measured number, and the stated range covers the measured number.
By their numbers in this assay, from the lowest: compounds 2, 3 and 4 (each within the scatter of the next); then compound 1.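

In this assay, within the data shown here, the first exchange at this aromatic carbon, phenyl in place of tert-butyl, gives a 1.2-fold higher number from compound 2 to compound 4 (0.08 log units; within the scatter). The number therefore holds when a branched group without a ring gives way to a six-membered aromatic ring of carbon only, with 6 heavy atoms entering and 4 leaving. No supporting measurement bears on why the two groups read alike. From the compounds shown here alone, whether a carboxylic acid, an amine or a methoxy group on this aromatic carbon would hold the number stays open. So does the outcome of a longer chain in the shared core.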